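The source may report more compounds than this note shows. Statements on the series, on what has been measured and on what is new or still open speak of the compounds shown alone.

Measured compounds and their values:
Compound 1 `CCCCSC1=N[C@@H](C(=O)OC)[C@@H]2C(=O)N(c3ccccc3)C(=O)[C@H]12` — 82%
Compound 2 `CCSC1=N[C@H](C(=O)OC)[C@@H]2C(=O)N(c3ccccc3)C(=O)[C@H]12` — 89%
Compound 3 `CCCCSC1=N[C@H](C(=O)OC)[C@@H]2C(=O)N(c3ccccc3)C(=O)[C@H]12` — 89%

In a functional assay for inhibition, tested at 100 uM (on this read-out lower numbers stand for less inhibition and higher numbers for more inhibition at the one concentration tested (going by the name of the read-out)), compound 1 gives 82%. Its number is the low one of the three, but both of the others lie within the scatter of it: the change is a number 7 percentage points higher from compound 1 to compound 3 (within the scatter), which rests only on (the fact that compounds 1 and 3 differ only in the configuration as drawn), and compound 2 stands at 89% against compound 3 at 89%. The unmeasured compound 4 `COC(=O)[C@@H]1N=C(SCc2ccccc2)[C@H]2C(=O)N(c3ccccc3)C(=O)[C@H]21` differs from compound 1 in one place: phenyl in place of propyl on a saturated chain carbon bound to a sulfur. The measured step nearest to this one is no change at the digits printed from compound 2 to compound 3 (within the scatter), which shows that lengthening the chain carbons bound to the sulfur leaves the read-out where it was. Among the measured compounds shown here, no measured step places an aromatic ring in this position, so the new change goes beyond what the three measured compounds show. On that basis compound 4 is expected to stay close to compound 1, with the step estimated at a number 2 percentage points higher from compound 1 to compound 4 (within the scatter), that is, none beyond the scatter. Compound 4 is thus estimated at 84%, with a range from 70% to 95%.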

Compound 4, a percentage reported as inhibition, at one concentration (the size of the read-out at that concentration, not a potency): 98%
The estimate for compound 4 lay 14 percentage points below the measured number; the measured number lies above the stated range.
By their numbers in this assay, from the lowest: compounds 1, 2, 3 and 4 (each within the scatter of the next, the first and the last beyond it).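

In this assay, the change from propyl to phenyl on a saturated chain carbon bound to a sulfur gives a number 16 percentage points higher from compound 1 to compound 4 (beyond the scatter), so the read-out at this position does respond to at least one change. Among the compounds shown here, the only earlier step in this chain, no change at the digits printed from compound 2 to compound 3 (within the scatter), stayed within the scatter, and it involved no aromatic ring; this is the first step here to go beyond the scatter and the first to bring in an aromatic ring. Nothing available explains why this step occurs.

A single step cannot separate the presence of the aromatic ring from the larger size of the group that enters. A cyclohexyl group in place of phenyl, a phenethyl chain on the sulfur, or a methoxy group or fluorine on the phenyl ring could each help to settle this.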